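The source may report more compounds than this note shows. Statements on the series, on what has been measured and on what is new or still open speak of the compounds shown alone.

Measured so far in a functional assay on SK-N-SH cells (Homo sapiens) for inhibition, read by MTT assay, with a stated time of 72 h, tested at 30 uM; on this read-out higher numbers stand for more inhibition of growth at the one concentration tested and lower numbers for less inhibition of growth:
- compound 1 `C=CCc1ccc(OCc2cn(-c3ccccc3Cl)nn2)c(O)c1` gives 10.2%
- compound 2 `C=CCc1ccc(OCc2cn(-c3ccc(OC)cc3)nn2)c(O)c1` gives 31.5%

Compound 2 holds the higher of these two numbers, and its 31.5% lies beyond the scatter of the value for compound 1. The next compound to consider is compound 3 `C=CCc1ccc(OCc2cn(-c3ccccc3CO)nn2)c(O)c1`, with 2-(hydroxymethyl)phenyl in place of 4-methoxyphenyl on an aromatic nitrogen as the counted difference: 2-(hydroxymethyl)phenyl in place of 4-methoxyphenyl on an aromatic nitrogen. For the measured compounds named here, only one measured step touches this place, the modest a number 21.3 percentage points higher from compound 1 to compound 2 (beyond the scatter), and its lower end carries 2-chlorophenyl. Going by the values given here, no compound with a 2-(hydroxymethyl)phenyl group has been measured, so the analogy with the 2-substituted group of compound 1 is thin. A modest fall is expected, and the estimated change is a number 13.5 percentage points lower from compound 2 to compound 3 (beyond the scatter) in this assay, somewhat smaller than the measured step. The estimate for compound 3 is 18%, with an expected range of 6% to 34% for this compound.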

Compound 3, percent growth inhibition at one concentration: 12.9%
Compound 3: the middle estimate sits 5.1 percentage points above what was measured, within the range that was stated.
By their numbers in this assay, from the lowest: compounds 1 and 3 (each within the scatter of the next); then compound 2.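

In this assay, 2-(hydroxymethyl)phenyl in place of 4-methoxyphenyl on the aromatic nitrogen gives a number 18.6 percentage points lower from compound 2 to compound 3 (beyond the scatter), and the two groups have the same atoms, joined differently, so this position responds to the arrangement of those atoms and not only to their kind. Hydroxymethyl in place of chloro on an aromatic carbon gives a number 2.7 percentage points higher from compound 1 to compound 3 (within the scatter), so this read-out does not separate 2-(hydroxymethyl)phenyl from 2-chlorophenyl, and compound 2 stays apart from both. Nothing available explains these numbers.

From the compounds shown here alone, whether the higher number of compound 2 belongs to the methoxy group itself or to where it sits on the phenyl ring stays open. Plain phenyl, or an amine or a carboxylic acid in place of hydroxymethyl, would extend the comparison.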